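The source may report more compounds than this note shows. Statements on the series, on what has been measured and on what is new or still open speak of the compounds shown alone.

Measured so far:
compound 1, `COc1cc(NC(=O)Nc2cc(Nc3ccc(C)c(F)c3)ncn2)cc(OC)c1` — 39.7%
compound 2, `COc1cc(NC(=O)Nc2cc(Nc3cc(C(F)(F)F)ccc3OC)ncn2)cc(OC)c1` — 60%

The study follows a single step from compound 2 to a compound not yet tested. In a functional assay on NCI-H226 cells (Homo sapiens) for inhibition, read by MTT assay, with a stated time of 48 h, tested at 10 uM (on this read-out lower numbers stand for less inhibition and higher numbers for more inhibition at the one concentration tested (going by the name of the read-out)), compound 2 gives 60%, and in this assay compound 1 gives 39.7%. Of the two numbers in hand, compound 2 stands highest, and the gap between compound 2 and compound 1 lies beyond the usual scatter of this read-out. No pair of these compounds differs in just one place, so no step between measured compounds can be drawn on.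

Compound 3, `COc1cc(NC(=O)Nc2cc(Nc3cc(Br)ccc3OC)ncn2)cc(OC)c1`, is the next compound. It differs from compound 2 in one place: bromo in place of trifluoromethyl on an aromatic carbon. The change therefore keeps the shared core of compound 2 and alters only the group at that aromatic carbon.

Going by the values given here, with no measured step of this kind to lean on, the step from compound 2 to compound 3 is expected to be small and downward, about a number 8 percentage points lower from compound 2 to compound 3 (within the scatter), and may well fall within the scatter. On that expectation compound 3 is estimated at 52%, with a likely range from 32% to 70%.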

Compound 3, a percentage reported as inhibition, at one concentration (the size of the read-out at that concentration, not a potency): 42.7%
Estimate against measurement, compound 3: 9.3 percentage points above; low and high end bracket the measured number.
By their numbers in this assay, from the lowest: compounds 1 and 3 (each within the scatter of the next); then compound 2.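

In this assay, the change to bromo in place of trifluoromethyl, on an aromatic carbon para to a methoxy group, gives a number 17.3 percentage points lower from compound 2 to compound 3 (beyond the scatter), so the read-out does respond to the group held at this position. The wider change, 5-bromo-2-methoxyphenyl in place of 3-fluoro-4-methylphenyl on a nitrogen on an aromatic ring, gives a number 3 percentage points higher from compound 1 to compound 3 (within the scatter), which leaves those two groups unseparated in this assay and, among these three compounds, sets only compound 2, with its trifluoromethyl, apart from the others. No measurement at hand bears on why trifluoromethyl and bromo part in this way.

The compounds shown leave open how a chloro, a nitrile or an amine on this same aromatic carbon would compare with trifluoromethyl and bromo. They also leave open whether the step from trifluoromethyl to bromo would keep its size with the methoxy group replaced by an ethoxy group, and, since each compound has a reading at only one concentration, how these differences would appear across a range of concentrations.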